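A few compounds are considered here, and "the series" means these few. Any claim that something is new, unique, unknown or untested is made for them only; others in the source may bear on it.

In a functional assay on MDA-MB-435 cells (Homo sapiens) for antiproliferative activity, read by sulforhodamine B assay (a higher number here means a weaker inhibitor, a lower number a stronger inhibitor), compound 1 `CSc1ccc(N(C)c2nc(C)nc3ccccc23)cc1` gives 1.2 nM and compound 2 `COc1ccc(N(C)c2ncnc3ccccc23)cc1` gives 7.1 nM as its reading. Compound 2 therefore has the higher number of the two, meaning the weaker inhibitor, and the gap lies beyond the usual scatter. Compound 3 `CSc1ccc(N(C)c2ncnc3ccccc23)cc1` comes from compound 2 by a single swap. That swap methylsulfanyl in place of methoxy on an aromatic carbon puts methylsulfanyl in place of methoxy on an aromatic carbon, para to a large group. Among the compounds with values here, no measured pair shows this swap alone. Compound 1 also carries methylsulfanyl, but it differs from compound 2 in more than one place, so the gap between them cannot be credited to that group. Only a small change, within the scatter and with no firm direction, is therefore expected. The estimated step of a 1.1-fold higher number from compound 2 to compound 3 (0.05 log units; within the scatter) reflects that caution. For compound 3 the expected value is 8 nM within an estimated range of 3 nM to 25 nM on present evidence.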

Compound 3, half-maximal inhibitory concentration: 7.8 nM
Compound 3: middle estimate off by 1.0-fold (0.01 log units), on the high side, and the stated range covers the measured number.
By their numbers in this assay, from the lowest: compound 1; then compounds 2 and 3 (each within the scatter of the next).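

In this assay the exchange of methoxy for methylsulfanyl, para to a large group, gives a 1.1-fold higher number from compound 2 to compound 3 (0.04 log units; within the scatter) and so leaves the two groups indistinguishable at this position in this read-out. Within the data shown here, compound 3 also provides the first comparison of a single change on the core, where hydrogen in place of methyl on an aromatic carbon gives a 6.5-fold higher number from compound 1 to compound 3 (0.81 log units; beyond the scatter) as a modest step beyond the scatter, making this the only one of the two single changes with a clear gap. Nothing available here explains the size of either step.

As far as these compounds go, it remains open whether an amine, a chlorine or an ethoxy at the para position would also match methoxy and methylsulfanyl. Also open, from the compounds shown here alone, is whether a longer chain such as ethyl could replace the methyl on the core and keep the lower number.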